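Cyano to chloro on the aryl thiourea

The source may report more compounds than this note shows. Statements on the series, on what has been measured and on what is new or still open speak of the compounds shown alone.

Measured so far in a functional assay on thoracic aorta (Rattus norvegicus) for inhibition; a lower number here means that less compound is needed, a higher number that more compound is needed for the effect:
- compound 1 `CC1(C)CC(NC(=S)Nc2cccc(C#N)c2)c2cc(NS(C)(=O)=O)ccc2O1` gives 9800 nM
- compound 2 `CC1(C)CC(NC(=O)Nc2cccc(Cl)c2)c2cc(NS(C)(=O)=O)ccc2O1` gives 15200 nM
- compound 3 `CCS(=O)(=O)Nc1ccc2c(c1)C(NC(=S)Nc1cccc(C#N)c1)CC(C)(C)O2` gives 12100 nM

Compound 3 stands second highest of the three numbers. Its nearest neighbour is compound 1, with a 1.2-fold higher number from compound 1 to compound 3 (0.09 log units; within the scatter); its furthest is compound 2, whose value lies on the other side of compound 3 but also within the scatter. All three numbers sit within the scatter of one another, so no order among them can be claimed.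

Compound 4 `CCS(=O)(=O)Nc1ccc2c(c1)C(NC(=S)Nc1cccc(Cl)c1)CC(C)(C)O2` is not yet measured in this assay. It differs from compound 3 in one place: chloro in place of cyano on an aromatic carbon. For the measured compounds named here, no measured step isolates this change. Going by the values given here, compound 1 and compound 2 carry the same two aryl groups but also differ in the thiourea against urea link, so their two values show only that the pair lies within the scatter of each other and give no clean reading of the chloro for cyano exchange alone. Among the compounds with values here, the single measured step, a 1.2-fold higher number from compound 1 to compound 3 (0.09 log units; within the scatter), concerns the sulfonyl chain and did not move the number beyond the scatter.

Within the data shown here, with no measured step bearing directly on the change, compound 4 is expected to come out close to compound 3, a step of a 1.1-fold higher number from compound 3 to compound 4 (0.03 log units; within the scatter) that stays within the scatter. Compound 4 is estimated at 13000 nM in this assay, with a range of 5000 nM to 35000 nM.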

Compound 4, half-maximal effective concentration: 9800 nM
For compound 4 the middle estimate is 1.3-fold (0.12 log units) above the measured one; low and high end bracket the measured number.
By their numbers in this assay, from the lowest: compounds 1, 4, 3 and 2 (each within the scatter of the next).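

For the compounds shown here, with the ethylsulfonyl group and the thiourea link held fixed, compound 3 and compound 4 give the first clean reading at this aromatic carbon in this assay: the step from 3-cyanophenyl to 3-chlorophenyl (a 1.2-fold lower number from compound 3 to compound 4 (0.09 log units; within the scatter)) stays within the scatter. This position therefore accepts the exchange of cyano for chloro without a readable shift, even though the triple bond and the hydrogen-bond acceptor of cyano leave and a single chlorine enters, so the earlier uncertainty about this exchange, which the urea compound could not resolve, is narrowed for the thiourea with the ethylsulfonyl group. Nothing at hand gives a reason for this outcome or ties it to any property of the two groups.

Going by these compounds alone, whether this position responds at all remains open, as cyano and chloro are the only two groups seen here, and an amine, a carboxylic acid or a methoxy group at the same aromatic carbon could yet give a step beyond the scatter. Also open is the exchange of thiourea for urea on its own, since no pair shown differs in that link alone.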